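The compounds below may be only part of what the source reports. "The series", "measured", "known", "first", "only" and "open" are said of these compounds alone.

Working notes on the series. Compound 1 `COC1=C(OC)C(=O)C(CCCCCCn2cc(C[C@H](O)COCCOC[C@@H](O)Cc3ccc(-c4ccccc4)cc3)nn2)=C(C)C1=O` gives 16700 nM in a functional assay on SGC-7901 cells (Homo sapiens) for inhibition, read by MTT assay, with a stated time of 72 h; on this read-out lower numbers stand for stronger inhibition of growth and higher numbers for weaker inhibition of growth. Compound 2 `O[C@H](COCCOC[C@@H](O)Cc1cn(-c2cncnc2)nn1)Cc1ccc(-c2ccccc2)cc1` is recorded in this assay only as a limit, > 100000 nM, and not as a number. The point at which that value sits is the limit of > 100000 nM in this assay, at which 1 of the 2 values shown sits. Compound 2 therefore stands at the weak end of the numbers shown, with no measured number of its own, and no step between measured compounds links it to compound 1.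

Compound 3 `O[C@H](COCCOC[C@@H](O)Cc1cn(-c2ccc3[nH]ccc3c2)nn1)Cc1ccc(-c2ccccc2)cc1` has not yet been measured. It differs from compound 2 by one change, 1H-indol-5-yl in place of pyrimidin-5-yl on an aromatic nitrogen. With compound 2 known only as a limit, the expected step in this assay can only be set loosely. The estimate is a move toward a measurable but still weak number, an at least 2.5-fold lower number from compound 2 to compound 3 (0.39 log units; beyond the scatter). Compound 3 is expected to give 40000 nM, within 8000 nM to 150000 nM.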

Compound 3, concentration for 50% growth inhibition: 45600 nM
Estimate against measurement, compound 3: 1.1-fold (0.06 log units) below, and the stated range covers the measured number.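

In this assay, the group on the aromatic nitrogen of the five-membered ring with 3 nitrogen proves able to shift the read-out: 1H-indol-5-yl in place of pyrimidin-5-yl gives an at least 2.1-fold lower number from compound 2 to compound 3 (0.34 log units; beyond the scatter). Compound 2 is recorded only as a limit, > 100000 nM. The true size of the step therefore stays unfixed, and only its minimum can be read: the limit of > 100000 nM in this assay, at which 1 of the 3 values shown sits.

The change swaps pyrimidin-5-yl for a larger group with a second ring and a hydrogen-bond donor, and this single pair cannot show which of these differences carries the step. Open too, going by these compounds, is how a plain phenyl or a 1-methylindol-5-yl on the same nitrogen would read, the latter keeping both rings without the hydrogen on the indole nitrogen.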